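Swapping an acetamide for a nitro group on a shared core

The source may hold more compounds than are shown below. What is called first, only, known or untested is meant among the compounds shown, and "the series" means these compounds.

Of the compounds shown here, three built on one shared core have been measured in an ADME assay on MT4 cells (Homo sapiens) for cytotoxicity, read by MTT assay, with a stated time of 96 h; a higher number here means that more compound is tolerated, a lower number that less compound is tolerated. Compound 1 `O=C(CN1CCCCC1)Nc1ccc(-c2nc3cc(C(F)(F)F)ccc3[nH]2)cc1` gives 6000 nM. Compound 2 `CC(=O)Nc1ccc(-c2nc3ccccc3[nH]2)cc1` gives 100000 nM. Compound 3 `CC(=O)Nc1ccc(-c2nc3cc(C(F)(F)F)ccc3[nH]2)cc1` gives 19000 nM, the second highest of the three numbers, nearest to compound 1 and furthest from compound 2. Two single changes connect these compounds: the step of a 3.2-fold higher number from compound 1 to compound 3 (0.50 log units; beyond the scatter) was modest, and the step of a 5.3-fold lower number from compound 2 to compound 3 (0.72 log units; beyond the scatter) was modest as well. Compound 4 `O=[N+]([O-])c1ccc(-c2nc3cc(C(F)(F)F)ccc3[nH]2)cc1` is not yet measured and differs from compound 3 in one place: nitro in place of acetamido on an aromatic carbon. Neither measured step concerns this position; one involves a saturated chain carbon bound to a carbonyl carbon, the other an aromatic carbon of the shared core. For the measured compounds named here, nothing among the measured compounds therefore shows what this exchange does. The expected step for compound 4 in this assay is small, a 1.3-fold lower number from compound 3 to compound 4 (0.10 log units; within the scatter), within the scatter. Compound 4 is estimated at 15000 nM, with a range from 5000 nM to 50000 nM.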

Compound 4, half-maximal cytotoxic concentration: 6000 nM
Compound 4: middle estimate off by 2.5-fold (0.40 log units), on the high side; the measured number falls inside the stated range.
By their numbers in this assay, from the lowest: compounds 1 and 4 (each within the scatter of the next); then compound 3; then compound 2.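

In this assay, replacing acetamido with nitro on the aromatic carbon para to a large group gives a 3.2-fold lower number from compound 3 to compound 4 (0.50 log units; beyond the scatter), so compound 4 is tolerated at lower concentrations than compound 3. For the compounds shown here, this is the first direct sign that the group at this position affects the number, which the earlier steps could not show: they changed only the chain on the amide and a hydrogen on the shared core. No available evidence explains the shift, so the data show its direction and size but not its cause.

An amine or a carboxylic acid at the same place would help show whether the shift is particular to nitro or also appears with other groups. On these data alone, it also remains open whether nitro would produce a similar step on the core without trifluoromethyl, the core of compound 2.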